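A few compounds are considered here, and "the series" means these few. Any claim that something is new, unique, unknown or untested is made for them only; others in the source may bear on it.

Measured compounds:
compound 1 `CCOc1cc(NC(=O)NCc2cc(C)c(-c3cn(C)nc3C(F)(F)F)nn2)cc(C#N)n1` — 5500 nM
compound 2 `CCOc1cc(NC(=O)NCc2cc(C)c(-c3cn(C)nc3C(F)(F)F)nn2)cc(C)n1` — 4400 nM

In a functional assay on CHO cells for agonist activity at sphingosine 1-phosphate receptor 2 (Homo sapiens), read by fluorescence and calcium flux, with a stated time of 3 min (a lower number here means a stronger inhibitor, a higher number a weaker inhibitor), compound 2 gives 4400 nM, the lowest of the two numbers; its nearest neighbour is compound 1, and a 1.3-fold lower number from compound 1 to compound 2 (0.10 log units; within the scatter), so the two stand together within the scatter. Compound 3 `CCOc1nc(Cl)cc(NC(=O)NCc2cc(C)c(-c3cn(C)nc3C(F)(F)F)nn2)c1C` differs from compound 2 by 6-chloro-2-ethoxy-3-methylpyridin-4-yl in place of 2-ethoxy-6-methylpyridin-4-yl on an amide-type nitrogen. Within the data shown here, no measured step changes this group in the same way. Among the measured compounds shown here, the one step that touches the group on the amide-type nitrogen is a 1.3-fold lower number from compound 1 to compound 2 (0.10 log units; within the scatter), methyl in place of cyano on an aromatic carbon, and it stays within the scatter. Nothing measured therefore supports a step beyond the scatter in this assay in either direction, though the two changes together leave the outcome less certain than that single step. Compound 3 is expected near 4000 nM, within 1300 nM to 12000 nM, which means an expected step of a 1.1-fold lower number from compound 2 to compound 3 (0.04 log units; within the scatter).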

Compound 3, half-maximal inhibitory concentration: 4800 nM
The estimate for compound 3 lay 1.2-fold (0.08 log units) below the measured number, and the stated range covers the measured number.
By their numbers in this assay, from the lowest: compounds 2, 3 and 1 (each within the scatter of the next).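

In this assay, the 6-chloro-2-ethoxy-3-methylpyridin-4-yl group on the amide-type nitrogen gives a 1.1-fold higher number from compound 2 to compound 3 (0.04 log units; within the scatter) and a 1.1-fold lower number from compound 1 to compound 3 (0.06 log units; within the scatter). The earlier pair covered only methyl in place of cyano on an aromatic carbon; this result extends the same flat picture to a group carrying chloro and a differently placed methyl, so all three groups at this place stand within the scatter of one another. No supporting measurement bears on this result.

On these data alone, whether an amine or a carboxylic acid on this pyridine, or a longer chain in place of ethoxy, would move the number beyond the scatter stays open. As far as these compounds go, the separate contributions of the chloro and the methyl within the 6-chloro-2-ethoxy-3-methylpyridin-4-yl group also stay open.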